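The compounds below may be only part of what the source reports. "The series", "measured", "known", "first", "only" and "open" are said of these compounds alone.

Of the compounds shown here, two that share one core have been tested in an in vitro ADME assay on microsomes from liver (Homo sapiens) for metabolic stability, with a stated time of 15 min; on this read-out lower numbers stand for slow clearance and higher numbers for fast clearance. Compound 1 `CCc1nn2c(-c3c(C)cc(C)cc3OC)cccc2c1N(CC1CCOCC1)CC1CC1` gives 450 mL.min-1.g-1, and compound 2 `CCc1nn2c(-c3c(C)cc(C)cc3OC)cccc2c1N(CC1CC1)CC1CCOC1` gives 1350 mL.min-1.g-1, the higher of the two numbers, so compound 2 stands at the fast-clearance end of this small set. Compound 3 `CCc1nn2c(-c3c(C)cc(C)cc3OC)cccc2c1N(CCCF)CC1CC1` has not yet been measured. It differs from compound 2 in one side chain: 2-fluoroethyl in place of oxolan-3-yl on a saturated chain carbon bound to a nitrogen on an aromatic ring. In words, 2-fluoroethyl comes in place of oxolan-3-yl on a saturated chain carbon bound to a nitrogen on an aromatic ring. Among the measured compounds shown here, only one measured step bears on this change: a 3.0-fold higher number from compound 1 to compound 2 (0.48 log units; beyond the scatter), a modest step beyond the scatter, with oxolan-3-yl in place of oxan-4-yl at the same place. For the measured compounds named here, that step exchanges one ring for another, and no measured compound carries 2-fluoroethyl, so the data give no direction for the new change. No step beyond the scatter is therefore expected, and the expected step is a 1.4-fold lower number from compound 2 to compound 3 (0.13 log units; within the scatter). Compound 3 is estimated at 1000 mL.min-1.g-1, with an expected range from 450 mL.min-1.g-1 to 2200 mL.min-1.g-1.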

Compound 3, intrinsic clearance in microsomes: 1410 mL.min-1.g-1
Compound 3: middle estimate off by 1.4-fold (0.15 log units), on the low side; the range from low to high includes it.
By their numbers in this assay, from the lowest: compound 1; then compounds 2 and 3 (each within the scatter of the next).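

Within this assay, a ring on this chain carbon proves not to be needed for a number at the fast-clearance end of the set: the result is a 1.0-fold higher number from compound 2 to compound 3 (0.02 log units; within the scatter) and so cannot be told apart from no change, although 2-fluoroethyl has no ring, fewer heavy atoms and no hydrogen-bond acceptor. The other new comparison, a 3.1-fold higher number from compound 1 to compound 3 (0.50 log units; beyond the scatter) for 2-fluoroethyl in place of oxan-4-yl, is a modest step of the same kind as a 3.0-fold higher number from compound 1 to compound 2 (0.48 log units; beyond the scatter) and lies beyond the scatter. Of these three groups, oxan-4-yl in compound 1 alone stands apart, with oxolan-3-yl in compound 2 and 2-fluoroethyl in compound 3 together at the higher numbers, and no supporting measurement accounts for this difference.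

Three groups at one position cannot show whether the lower number belongs to oxan-4-yl alone or to a wider family of groups. A plain propyl chain without fluorine, or a chain ending in an amine or a carboxylic acid, could sit with compound 1, with compounds 2 and 3, or apart from both.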